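A Third Methoxy on the Side Chain of Compound 2

This account rests on a few compounds, and the source may have more. Where it says the series, first, only, none or still open, it means among the compounds named here.

Compound 2 `COc1ccc(CNc2nc3cc(N)cc(N)c3nc2-c2ccccc2)cc1OC` is tested in a functional assay on RPMI8266 cells (Homo sapiens) for inhibition, read by sulforhodamine B assay, with a stated time of 48 h (a higher number here means a weaker inhibitor of growth, a lower number a stronger inhibitor of growth), where compound 2 gives 7240 nM, the highest of the two numbers available. Compound 1 `Nc1cc(N)c2nc(-c3ccccc3)c(NCc3ccc(Cl)c(Cl)c3)nc2c1` gives 3720 nM in this assay, and the step of a 1.9-fold higher number from compound 1 to compound 2 (0.29 log units; within the scatter) is the only fully measured one. For compound 3 `CCOC(=O)[C@H](CCC(=O)O)NC(=O)c1ccc(Sc2nc3cc(N)cc(N)c3nc2-c2ccccc2)cc1` this assay reports only a limit, < 100000 nM (the limit of < 100000 nM in this assay, at which 1 of the 3 values shown sits), not a number. Compound 4 `COc1cc(CNc2nc3cc(N)cc(N)c3nc2-c2ccccc2)cc(OC)c1OC` differs from compound 2 by methoxy in place of hydrogen on an aromatic carbon. The measured step, which replaced the dichlorophenyl with the dimethoxyphenyl, stayed within the scatter, so one further methoxy is expected to shift the number in this assay little in either direction. Compound 4 is therefore estimated at 8000 nM, within the range 3000 nM to 22000 nM, a step of a 1.1-fold higher number from compound 2 to compound 4 (0.04 log units; within the scatter) that is expected to stay within the scatter.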

Compound 4, concentration for total growth inhibition: 3020 nM
Compound 4: middle estimate off by 2.6-fold (0.42 log units), on the high side, and the stated range covers the measured number.
By their numbers in this assay, from the lowest: compounds 4, 1 and 2 (each within the scatter of the next, the first and the last beyond it).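

On this aromatic carbon, ortho to a methoxy group and meta to a second one, adding a methoxy gives a step that clears the scatter in this assay: a 2.4-fold lower number from compound 2 to compound 4 (0.38 log units; beyond the scatter). Within the data shown here, this is the first fully measured step here to do so, which shows that the number responds to a small change at this position, though only modestly. Nothing measured here accounts for the change.

Going by these compounds, whether an amine or a carboxylic acid on this same carbon would move the number in the same direction stays open. So does whether a longer chain in place of the new methoxy would keep the step.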